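The source may hold more compounds than are shown below. What is called first, only, known or untested is meant among the compounds shown, and "the series" means these compounds.

Of the compounds shown here, three have so far been measured in a functional assay on microsomes for inhibition, with a stated time of 1 h; a lower number here means a stronger inhibitor, a higher number a weaker inhibitor. Compound 1, `CSc1nc(-c2ccco2)c(C#N)c(=O)n1C`, gives 90 ug/mL. Compound 2, `CSc1nc(-c2cccs2)c(C#N)c(=O)n1C`, gives 83 ug/mL in this assay. Compound 3, `CCOC(=O)c1cnn(-c2nc(-c3ccco3)c(C#N)c(=O)n2C)c1N`, gives 116 ug/mL in this assay. All three numbers lie within the usual scatter of one another, so none of the three can be called a stronger or weaker inhibitor than the others.

Compound 1 and compound 2 differ in a single place: thiophen-2-yl in place of furan-2-yl on an aromatic carbon. That change produced a 1.1-fold lower number from compound 1 to compound 2 (0.04 log units; within the scatter).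

Compound 4, `CCOC(=O)c1cnn(-c2nc(-c3cccs3)c(C#N)c(=O)n2C)c1N`, has not yet been measured in this assay. It differs from compound 3 in one place: thiophen-2-yl in place of furan-2-yl on an aromatic carbon. How the core of compound 3 differs from the core of compound 1 is not broken down here. The surroundings of the changed carbon are not quite alike either: in compound 1 it is meta to a methylsulfanyl group (2 heavy atoms), whereas in compound 3 it is meta to a large group. The change from compound 3 to compound 4 is therefore the same kind of change as that from compound 1 to compound 2, not the same.

The step is expected to be a 1.1-fold lower number from compound 3 to compound 4 (0.04 log units; within the scatter), a size expected because the same kind of change made a 1.1-fold lower number from compound 1 to compound 2 (0.04 log units; within the scatter). Compound 4 is thus estimated at 105 ug/mL in this assay, with a likely range from 60 ug/mL to 180 ug/mL.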

Compound 4, half-maximal inhibitory concentration: 97 ug/mL
Compound 4: the middle estimate sits 1.1-fold (0.03 log units) above what was measured; measured number inside the range.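

In this assay, putting thiophen-2-yl in place of furan-2-yl on the core of compound 3 gave a 1.2-fold lower number from compound 3 to compound 4 (0.08 log units; within the scatter), so on this core the two rings cannot be told apart by this measurement. Set beside the same swap on the core of compound 1, the step looks much the same on both cores: the same change on two cores in this assay, a 1.1-fold lower number (0.04 log units; within the scatter) from compound 1 to compound 2 and a 1.2-fold lower number (0.08 log units; within the scatter) from compound 3 to compound 4, 1.1-fold (0.04 log units) apart, within the scatter of two such steps This shows only that the swap made no readable difference on either of these two cores; since neither step rises above the scatter, the agreement is between two steps that cannot be told from no change, and it does not show that a step of real size would carry over from one core to the other, or that the same would hold on any further core.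

As far as these compounds go, all four compounds carry either furan-2-yl or thiophen-2-yl at this place, so it remains open whether a quite different group there, such as an amine, a carboxylic acid or a longer alkyl chain, would move the number beyond the scatter. Whether any change at this place can alter inhibition in this series is therefore still unanswered.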